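This account rests on a few compounds, and the source may have more. Where it says the series, first, only, none or still open, it means among the compounds named here.

Measured compounds:

Compound 1, `COC1Cc2sccc2C2(CCN(CCCc3ccccc3)CC2)O1` — in an assay on membranes from brain for displacement of a labelled ligand from Sigma non-opioid intracellular receptor 1 (Cavia porcellus) (a lower number here means a stronger inhibitor, a higher number a weaker inhibitor), compound 1 gives 2.4 nM.
Compound 2, `COC1Cc2sccc2C2(CCN(Cc3ccc(F)cc3)CC2)O1` — in this assay compound 2 gives 0.62 nM.

Of these two numbers, compound 2 has the lower one; the measured step is a 3.9-fold lower number from compound 1 to compound 2 (0.59 log units; beyond the scatter), which comes from putting 4-fluorophenyl in place of phenethyl on a saturated chain carbon bound to an amine nitrogen in a ring.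

Compound 3, `COC1Cc2sccc2C2(CCN(Cc3cccs3)CC2)O1`, has not yet been measured. It differs from compound 2 in one place: thiophen-2-yl in place of 4-fluorophenyl on a saturated chain carbon bound to an amine nitrogen in a ring. Among the compounds with values here, the only measured step, a 3.9-fold lower number from compound 1 to compound 2 (0.59 log units; beyond the scatter), changes the chain as well as the ring and so bears only loosely on a swap of one aromatic ring for another at the same place. Within the data shown here, no measured pair shows what exchanging 4-fluorophenyl for thiophen-2-yl does here, so the expectation rests on compound 2 alone, with a wide range in this assay.

For compound 3 the expected step is a 1.6-fold higher number from compound 2 to compound 3 (0.21 log units; within the scatter), within the scatter. Compound 3 is therefore estimated at 1 nM, with a range from 0.3 nM to 3.5 nM.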

Compound 3, inhibition constant: 2 nM
Compound 3: the middle estimate sits 2.0-fold (0.30 log units) below what was measured; measured number inside the range.
By their numbers in this assay, from the lowest: compound 2; then compounds 3 and 1 (each within the scatter of the next).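

In this assay the exchange of one aromatic ring for another on this saturated chain carbon can now be read on its own: thiophen-2-yl in place of 4-fluorophenyl gives a 3.2-fold higher number from compound 2 to compound 3 (0.51 log units; beyond the scatter), so this position does respond to the identity of the ring. Thiophen-2-yl in place of phenethyl gives a 1.2-fold lower number from compound 1 to compound 3 (0.08 log units; within the scatter), which leaves compound 2 as the strongest inhibitor of the three, with the other two level with each other. Nothing available explains the preference for 4-fluorophenyl over thiophen-2-yl.

Still open, on these data alone, is whether the lower number of compound 2 goes with the fluorine or with the six-membered ring, a question that a plain phenyl on the same carbon could settle. Also open, as far as these compounds go, is how other rings at this place, such as thiophen-3-yl or a pyridine, would compare.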